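Methoxy added to the aryl ring of compound 1

A few compounds are considered here, and "the series" means these few. Any claim that something is new, unique, unknown or untested is made for them only; others in the source may bear on it.

Measured so far:
compound 1 `COc1ccc(-c2cc(/C=C/C(=O)c3ccc(N)cc3)[nH]n2)cc1` — 1690 nM
compound 2 `COc1cc(-c2cc(/C=C/C(=O)c3ccc(Cl)c(Cl)c3)[nH]n2)cc(OC)c1OC` — 8630 nM

In a functional assay on SW-620 cells (Homo sapiens) for inhibition, read by sulforhodamine B assay, with a stated time of 48 h (on this read-out lower numbers stand for stronger inhibition of growth and higher numbers for weaker inhibition of growth), compound 1 gives 1690 nM and compound 2 gives 8630 nM; compound 1 holds the lowest of the two numbers, and its gap to compound 2 lies beyond the scatter. Compound 3 `COc1ccc(-c2cc(/C=C/C(=O)c3ccc(N)cc3)[nH]n2)cc1OC` is not yet measured. Relative to compound 1 it carries methoxy in place of hydrogen on an aromatic carbon. Among the compounds with values here, no directly comparable step is available among the measured compounds, so no change beyond the scatter is expected from this assay. Compound 3 is estimated at 2100 nM, range 700 nM to 6500 nM, the expected step being a 1.2-fold higher number from compound 1 to compound 3 (0.09 log units; within the scatter).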

Compound 3, concentration for 50% growth inhibition: 2500 nM
The estimate for compound 3 lay 1.2-fold (0.08 log units) below the measured number; the range from low to high includes it.
By their numbers in this assay, from the lowest: compounds 1 and 3 (each within the scatter of the next); then compound 2.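

In this assay, methoxy in place of hydrogen on the aromatic carbon ortho to a methoxy group gives a 1.5-fold higher number from compound 1 to compound 3 (0.17 log units; within the scatter). Within the data shown here, this position therefore tolerates the added methoxy, which is the first single-place comparison. No available evidence bears on this result. Open, going by these compounds, is whether a hydroxy group, a fluorine atom or a longer chain such as ethoxy on this same carbon would also stay within the scatter. A single pair also leaves open whether the methoxy result carries over to other members of the series.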